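This account rests on a few compounds, and the source may have more. Where it says the series, first, only, none or still open, it means among the compounds named here.

In a functional assay on ECa-109 cells for inhibition, with ECa-109 cell line (Homo sapiens) as the target, read by sulforhodamine B assay (on this read-out lower numbers stand for stronger inhibition and higher numbers for weaker inhibition), compound 1 `O=C1C=C(NC2CCCCC2)C(=O)c2c1nc1n2[C@H]2OC[C@@H](O)[C@H]2OC1` gives > 16000 nM, which is a limit and not a number. Among the compounds with values here, compound 2 `O=C1C=C(Nc2ccc(Br)cc2)C(=O)c2c1nc1n2[C@H]2OC[C@@H](O)[C@H]2OC1` gives 2850 nM, the only true number so far. Compound 3 `CCCN(CCC)C1=CC(=O)c2nc3n(c2C1=O)[C@H]1OC[C@@H](O)[C@H]1OC3` is still to be measured. It differs from compound 2 by dipropylamino in place of (4-bromophenyl)amino on a double-bonded ring carbon, with dipropylamino in place of (4-bromophenyl)amino on a double-bonded ring carbon. Within the data shown here, one measured step bears on this change: an at least 5.6-fold lower number from compound 1 to compound 2 (0.74 log units; beyond the scatter), with 4-bromophenyl in place of cyclohexyl on an amine nitrogen. One end of that step sits at the limit of > 16000 nM in this assay, at which 1 of the 2 values shown sits, so its size is only a bound. Compound 3, like compound 1, has no aromatic ring in this group, so the step of an at least 5.6-fold lower number from compound 1 to compound 2 (0.74 log units; beyond the scatter) suggests losing that ring will raise the number in this assay. The expected change, beyond the scatter, is a 3.2-fold higher number from compound 2 to compound 3 (0.50 log units; beyond the scatter). For compound 3 the estimate is 9000 nM, with an expected range of 3000 nM to 27000 nM.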

Compound 3, half-maximal inhibitory concentration: > 16000 nM
Compound 3: no number, only a limit; the forecaster's own chance of this, stated with the estimate: 35%; at least 1.7-fold (0.24 log units) between middle value and limit.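

In this assay, dipropylamino in place of (4-bromophenyl)amino on the double-bonded ring carbon gives an at least 5.6-fold higher number from compound 2 to compound 3 (0.74 log units; beyond the scatter), so a second group without an aromatic ring, after the cyclohexylamino of compound 1, also gives no true number. Compound 3 stops at a limit too, so this step is only a bound, and the step from compound 1 to compound 3 cannot be read: the limit of > 16000 nM in this assay, at which 2 of the 3 values shown sit.

Of the compounds shown, only compound 2, which carries the aromatic ring, gives a true number, 2850 nM.

The change to compound 3 removes the aromatic ring and the hydrogen-bond donor of (4-bromophenyl)amino together, and the compounds shown do not separate the two. They also leave open what the bromine contributes, a question that a plain phenylamino or a benzylamino group at this carbon would bear on.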